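The source may hold more compounds than are shown below. What is called first, only, known or untested is meant among the compounds shown, and "the series" means these compounds.

Working notes on the series, all read in an ADME assay on L132 cells (Homo sapiens) for cytotoxicity, read by MTT assay, with a stated time of 72 h; on this read-out lower numbers stand for stronger inhibition and higher numbers for weaker inhibition. Compound 2 (`COc1ccc(C2=C(c3cc(OC)c(OC)c(OC)c3)C(=O)C(OC(C)=O)C2)cc1F`) gives < 1 ug/mL, which is a limit of the assay and not a number. Compound 3 (`COc1ccc(C2=C(c3cc(OC)c(OC)c(OC)c3)C(=O)C(O)C2)cc1F`) gives < 1 ug/mL, again a limit. Compound 1 (`COc1ccc(C2=C(c3cc(OC)c(OC)c(OC)c3)C(=O)C(OC(C)=O)C2)cc1`) gives > 100 ug/mL, also a limit. Compound 2 therefore has no exact position and stands at the limit of < 1 ug/mL in this assay, at which 2 of the 3 values shown sit.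

Compound 4 (`COc1ccc(C2=C(c3cc(OC)c(OC)c(OC)c3)C(=O)C(OC(C)=O)C2)cc1O`) differs from compound 2 as follows: hydroxy in place of fluoro on an aromatic carbon. This is hydroxy in place of fluoro on an aromatic carbon, ortho to a methoxy group and meta to a large group.

Fluoro in place of hydrogen at this same aromatic carbon gave an at least 100-fold lower number from compound 1 to compound 2 (2.00 log units; beyond the scatter), a large step. Compound 4 also carries a group other than hydrogen there, so it is expected to stay with compound 2 rather than fall back to compound 1. Hydrogen in place of acetyl on an oxygen gave a step that the two limits leave unreadable from compound 2 to compound 3, and that change lies elsewhere, so it offers little guidance here. Among the measured compounds shown here, no measured compound yet carries hydroxy on the aromatic carbon, so the range stays wide.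

The expected result is a step that the limit leaves unreadable from compound 2 to compound 4, with no step beyond the scatter anticipated in either direction. For compound 4 the estimated value is 0.5 ug/mL, within an expected range of 0.05 ug/mL to 5 ug/mL.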

Compound 4, half-maximal inhibitory concentration: 6 ug/mL
For compound 4 the middle estimate is 12-fold (1.08 log units) below the measured one; the whole stated range lies below it.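

In this assay, among the compounds shown here, the gain at this aromatic carbon does not come equally from every group other than hydrogen: hydroxy in place of fluoro gives an at least 6.0-fold higher number from compound 2 to compound 4 (0.77 log units; beyond the scatter) and so separates two groups that the earlier compounds could not compare. Hydroxy nevertheless keeps a clear distance from the unsubstituted ring, with an at least 16-fold lower number from compound 1 to compound 4 (1.22 log units; beyond the scatter) as the step for hydroxy in place of hydrogen, so the series now shows an order of fluoro, hydroxy and hydrogen at this one position on the shared core. Nothing at hand gives a measured property that would account for this order.

From the compounds shown here alone, compound 2 gives < 1 ug/mL in this assay, which is a limit of the assay and not a number, so the true size of the step away from fluoro stays open. Also open, going by these compounds, is whether an amine or a chlorine atom on this aromatic carbon would stay with fluoro or with hydroxy, and whether the hydroxy on the saturated carbon, which replaces acetyl in compound 3, would change the result when paired with the 3-hydroxy-4-methoxyphenyl group.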